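From Benzyl to Butoxy: Expecting a Modest Loss

The compounds below may be only part of what the source reports. "The series", "measured", "known", "first", "only" and "open" are said of these compounds alone.

In a functional assay on OVCAR-3 cells (Homo sapiens) for inhibition, read by sulforhodamine B assay, with a stated time of 48 h (on this read-out higher numbers stand for weaker inhibition of growth and lower numbers for stronger inhibition of growth), three compounds have numbers so far:
Compound 1 `O=C(Nc1ccccc1OC(F)(F)F)Nc1n[nH]c2ccccc12` gives 90800 nM.
Compound 2 `Nc1nn(C(=O)Nc2ccc(Cc3ccccc3)cc2)c2ccccc12` gives 6230 nM.
Compound 3 `COc1ccccc1NC(=O)n1nc(N)c2ccccc21` reaches only a limit of the assay, > 100000 nM.

Compound 2 holds the lowest of the two true numbers; compound 1 lies far beyond the scatter from it, on the weaker side. Compound 3 sits at the limit of > 100000 nM in this assay, at which 1 of the 3 values shown sits, so it gives no number to compare.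

Compound 4 `CCCCOc1ccc(NC(=O)n2nc(N)c3ccccc32)cc1` differs from compound 2 by butoxy in place of benzyl on an aromatic carbon. Among the compounds with values here, no measured pair shows this kind of exchange, so the expectation rests on the loose pattern that the weaker compounds carry other substituents. A moderate weakening, about at the edge of the scatter, is expected: compound 4 is estimated at 15000 nM, between 4000 nM and 60000 nM, a step of a 2.4-fold higher number from compound 2 to compound 4 (0.38 log units; beyond the scatter).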

Compound 4, concentration for 50% growth inhibition: 18800 nM
For compound 4 the middle estimate is 1.3-fold (0.10 log units) below the measured one; measured number inside the range.
By their numbers in this assay, from the lowest: compound 2; then compound 4; then compound 1. At a limit, above all of these: compound 3.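

Putting butoxy in place of benzyl gives a 3.0-fold higher number from compound 2 to compound 4 (0.48 log units; beyond the scatter) in this assay, so at this place, on an aromatic carbon para to a large group, the second aromatic ring can be given up at a modest cost. The change also adds an oxygen and shortens the group, so this single step carries several differences at once. Nothing measured here accounts for the step. From the compounds shown here alone, whether the ring or the oxygen matters more stays open: a phenoxy group or a plain hexyl chain at this place would help separate the two.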